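A 4-Hydroxyphenyl Swap Close to the Assay Limit

The source may report more compounds than this note shows. Statements on the series, on what has been measured and on what is new or still open speak of the compounds shown alone.

In a functional assay on NCI-H520 cells (Homo sapiens) (on this read-out lower numbers stand for stronger inhibition of growth and higher numbers for weaker inhibition of growth), compound 1 (`O=S(=O)(/C=C/c1ccccc1)Cc1ccc(Nc2ncnc3ccccc23)cc1`) gives > 100000 nM, which is a limit of the assay and not a number. Among the compounds with values here, compound 2 (`O=S(=O)(/C=C/c1ccc(F)cc1Cl)Cc1ccc(Nc2ncnc3ccccc23)cc1`) gives 100000 nM, the only actual number so far in this assay. Within the data shown here, the one measured step is a number no higher from compound 1 to compound 2 (the limit leaves the size open), and it changes the group at the same place as the next step. Compound 3 (`O=S(=O)(/C=C/c1ccc(O)cc1)Cc1ccc(Nc2ncnc3ccccc23)cc1`) follows with this change: 4-hydroxyphenyl in place of 2-chloro-4-fluorophenyl on a double-bonded chain carbon bound to a double-bonded chain carbon. Here 4-hydroxyphenyl takes the place of 2-chloro-4-fluorophenyl on a double-bonded chain carbon bound to a double-bonded chain carbon. The measured step gives no readable size to carry over, so the expectation stays anchored on compound 2 at 100000 nM. The expected change, a 1.4-fold lower number from compound 2 to compound 3 (0.15 log units; within the scatter), stays within the usual scatter, with no firm direction. Compound 3 is estimated at 70000 nM, with an expected range of 20000 nM to 100000 nM.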

Compound 3, concentration for 50% growth inhibition: 100000 nM
Compound 3: middle estimate off by 1.4-fold (0.15 log units), on the low side; low and high end bracket the measured number.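

In this assay, 4-hydroxyphenyl in place of 2-chloro-4-fluorophenyl gives no change at the digits printed from compound 2 to compound 3 (within the scatter), so at this place a group with a hydrogen-bond donor and a group without one read alike. Compound 1 gives > 100000 nM, which is a limit of the assay and not a number. Hydroxy in place of hydrogen on an aromatic carbon gives a number no higher from compound 1 to compound 3 (the limit leaves the size open). The flat step may say little about either group, since the values of the three compounds all lie at one edge of the scale: the limit of > 100000 nM in this assay, at which 1 of the 3 values shown sits.

Still open, from the compounds shown here alone, is whether an amine or a carboxylic acid on the phenyl ring would bring the number in this assay clearly down. Also open, going by these compounds, is whether this same swap would read differently on a compound whose number lies well away from that limit.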